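The source may report more compounds than this note shows. Statements on the series, on what has been measured and on what is new or still open speak of the compounds shown alone.

Measured so far in an in vitro functional assay on 1321-N1 cells for agonist activity at P2Y purinoceptor 4 (Homo sapiens), read by scintillation proximity assay and inositol phosphate accumulation; on this read-out higher numbers stand for an effect only at larger amounts of compound and lower numbers for an effect already at smaller amounts:
Compound 1 `Nc1nc(=O)ccn1[C@@H]1O[C@H](COP(=O)(O)OP(=O)(O)O)[C@@H](O)[C@H]1O` gives >= 100000 nM, which is a limit of the assay rather than a number.
Compound 2 `O=c1[nH]c(=S)ccn1[C@@H]1O[C@H](COP(=O)(O)O)[C@@H](O)[C@H]1O` gives > 100000 nM, again a limit of the assay.
Compound 3 `Nc1nc(=O)ccn1[C@@H]1O[C@H](COP(=O)(O)O)[C@@H](O)[C@H]1O` gives 4980 nM.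

Within the data shown here, compound 1 therefore stands at the limit of >= 100000 nM in this assay, at which 1 of the 3 values shown sits, the only firm statement about it being that no number was reached; compound 2 sits at the limit of > 100000 nM in this assay, at which 1 of the 3 values shown sits, and compound 3 is the one compound of the three with a measured number. Among the measured compounds shown here, the single step with a number behind it, an at least 20-fold lower number from compound 1 to compound 3 (1.30 log units; beyond the scatter), removes the terminal phosphate group rather than touching the base.

Compound 4 `CCCSc1nc(=O)ccn1[C@@H]1O[C@H](COP(=O)(O)OP(=O)(O)O)[C@@H](O)[C@H]1O` differs from compound 1 only at the base: propylsulfanyl in place of amino on an aromatic carbon. For the measured compounds named here, no measured pair changes this position, so none of the measured steps bears directly on it; the change from compound 1 to compound 3 concerns a different part of the molecule and only shows how far compound 1 can move once a number appears. With compound 1 at a limit, any estimate starts from that limit and carries wide uncertainty.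

Compound 4 is expected to give 40000 nM in this assay, within 5000 nM to 200000 nM, that is an estimated at least 2.5-fold lower number from compound 1 to compound 4 (0.39 log units; beyond the scatter).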

Compound 4, half-maximal effective concentration: 4900 nM
Beside the measured number, compound 4's estimate is 8.2-fold (0.91 log units) above it; measured number outside the range, below it.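

In this assay the base change alone yields a measured number, with an at least 20-fold lower number from compound 1 to compound 4 (1.30 log units; beyond the scatter), so propylsulfanyl between two ring nitrogen atoms gives a read-out at smaller amounts of compound while the terminal phosphate group stays in place. Among these compounds, until now the only step with a number behind it lay at the phosphate end of the molecule, with an at least 20-fold lower number from compound 1 to compound 3 (1.30 log units; beyond the scatter), whereas this step shows that the position holding the amino group also governs the read-out and can take a larger group with no hydrogen-bond donor. The true size of the new step stays open-ended because compound 1 rests at a limit of the assay rather than at a number: the limit of >= 100000 nM in this assay, at which 1 of the 4 values shown sits.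

The compounds shown do not separate the sulfur from the chain, and a shorter methylsulfanyl, a longer butylsulfanyl or an oxygen-linked propoxy group at this position would be needed to do so. Also open, going by these compounds, is whether propylsulfanyl would act in the same way on compound 3, as compound 3 and compound 4 differ in two places and offer no such reading.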